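This account rests on a few compounds, and the source may have more. Where it says the series, first, only, none or still open, it means among the compounds named here.

Measured compounds:
Compound 1 `COc1ccc(-c2c(I)c(=O)c3c(OC)cc(OC)cc3n2S(=O)(=O)c2ccc(OC)cc2)cc1` gives 12300 nM in a functional assay on SUP-B15 cells (Homo sapiens) for antiproliferative activity, with a stated time of 72 h; a higher number here means that more compound is needed for the effect, a lower number that less compound is needed.
Compound 2 `COC(=O)c1cc(=O)c2c(OC)cc(OC)cc2n1C` is reported only as a limit, > 37900 nM.
Compound 3 `COc1ccc(-c2cc(=O)c3c(OC)cc(OC)cc3n2S(=O)(=O)c2ccc([N+](=O)[O-])cc2)cc1` gives 17100 nM in this assay.

Of the three, only compound 1 and compound 3 have a number rather than a limit. Compound 3 gives one of those two numbers and compound 1 the other, and the difference between them is within the scatter, so the two are not distinguished. Compound 2 sits at the limit of > 37900 nM in this assay, at which 1 of the 3 values shown sits. Among the measured compounds shown here, since no two of the measured compounds differ in a single place, no measured step is available.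

Compound 4 `COc1ccc(-c2cc(=O)c3c(OC)cc(OC)cc3n2S(=O)(=O)c2c(F)c(F)c(F)c(F)c2F)cc1` is not yet measured. It differs from compound 3 in one place: 2,3,4,5,6-pentafluorophenyl in place of 4-nitrophenyl on a sulfonyl sulfur. The measured compounds carry either 4-methoxyphenyl or 4-nitrophenyl at this position, and these two give values within the scatter of each other, so the data give no sign that this position moves the number much. The step from compound 3 to compound 4 is therefore expected to be small, a 1.1-fold lower number from compound 3 to compound 4 (0.06 log units; within the scatter), in no direction that goes beyond the scatter. For compound 4 the expected value in this assay is 15000 nM, with a range from 5000 nM to 40000 nM.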

Compound 4, half-maximal effective concentration: 4100 nM
Compound 4: the middle estimate sits 3.7-fold (0.56 log units) above what was measured, outside the stated range (below it).
By their numbers in this assay, from the lowest: compound 4; then compounds 1 and 3 (each within the scatter of the next). At a limit, above all of these: compound 2.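

In this assay, among the compounds shown here, 2,3,4,5,6-pentafluorophenyl in place of 4-nitrophenyl on a sulfonyl sulfur gives a 4.2-fold lower number from compound 3 to compound 4 (0.62 log units; beyond the scatter), the first step here in which this position alone changes. It shows that the group on the sulfonyl sulfur can move the number beyond the scatter while the rest of the molecule stays the same, something compound 1 and compound 3 could not show, as they differ in more than one place and no single change can be read from that pair. None of the measurements shown bears on why the number falls with this change.

This single step does not tell whether the lower number goes with the five fluorines on the ring or with the departure of the 4-nitrophenyl group, and a plain phenyl or a 4-fluorophenyl on the sulfonyl sulfur would be needed to separate the two. As far as these compounds go, it also remains open how an aminophenyl or a carboxyphenyl group at this position would behave, and whether the same change would give a step of similar size on the core of compound 1, which carries iodine.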